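Side chain on the ring amine nitrogen: compound 2 to compound 3

This account rests on a few compounds, and the source may have more. Where it says the series, first, only, none or still open, it means among the compounds named here.

Among the measured compounds shown here, compound 2 `CC(C)c1nc(C(=O)NC2CCN(CC(C)(C)O)CC2)c2ccccn12` stands at 40 nM in a functional assay on CHO cells for agonist activity at 5-hydroxytryptamine receptor 4 (Homo sapiens), read by a luciferase reporter and cAMP accumulation, with a stated time of 4 h (a higher number here means that more compound is needed for the effect, a lower number that less compound is needed), the lowest of the two numbers so far. Compound 1 `CCN1CCC(NC(=O)c2nc(C(C)C)n3ccccc23)CC1` gives 50 nM in this assay. For the measured compounds named here, the one step in hand, a 1.3-fold lower number from compound 1 to compound 2 (0.10 log units; within the scatter), lies within the scatter. Compound 3 `CC(C)c1nc(C(=O)NC2CCN(CC3CCOC3)CC2)c2ccccn12` carries oxolan-3-yl in place of 1-hydroxy-1-methylethyl on a saturated chain carbon bound to an amine nitrogen in a ring. Going by the values given here, no measured step changes this position in the same way, and the only step at it, a 1.3-fold lower number from compound 1 to compound 2 (0.10 log units; within the scatter), was within the scatter and concerned a different group, so guidance is weak. No shift beyond the scatter is therefore expected in this assay: no change at the digits printed from compound 2 to compound 3 (within the scatter). Compound 3 is estimated at 40 nM, within a range of 15 nM to 120 nM.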

Compound 3, half-maximal effective concentration: 25 nM
Compound 3: the middle estimate sits 1.6-fold (0.20 log units) above what was measured, and the stated range covers the measured number.
By their numbers in this assay, from the lowest: compounds 3, 2 and 1 (each within the scatter of the next).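

Oxolan-3-yl in place of 1-hydroxy-1-methylethyl gives a 1.6-fold lower number from compound 2 to compound 3 (0.20 log units; within the scatter) in this assay, so at this position a ring with no hydrogen-bond donor reads the same as an open hydroxy-bearing group. Oxolan-3-yl in place of methyl gives a 2.0-fold lower number from compound 1 to compound 3 (0.30 log units; within the scatter) and likewise does not separate the side chains, leaving all three compounds unresolved in this read-out. No evidence bears on these results.

On these data alone, whether cyclopentyl, without the ring oxygen, reads the same remains open. So does whether a carboxylic acid or a longer chain on this carbon moves the number beyond the scatter.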